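The source may hold more compounds than are shown below. What is called first, only, known or untested is meant among the compounds shown, and "the series" means these compounds.

In a functional assay on MCF7 cells (Homo sapiens) for inhibition, read by MTT assay, with a stated time of 3 days (a higher number here means a weaker inhibitor, a lower number a stronger inhibitor), three compounds built on a shared core have been measured. Compound 1 (`COc1cc(-c2nc3ccccc3s2)ccc1OCC(=O)NNC(=O)CCl`) gives 780 nM, compound 2 (`COc1cc(-c2nc3ccccc3s2)ccc1OCC(=O)NNC(=O)CN[C@@H](CS)C(=O)O`) gives 1230 nM, and compound 3 (`COc1cc(-c2nc3ccccc3s2)ccc1OCC(=O)NNC(=O)CN[C@@H](CS(=O)(=O)O)C(=O)O`) gives 1870 nM. The number for compound 3 lies within the scatter of the number for compound 2 and beyond the scatter of the number for compound 1.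

The next compound is compound 4 (`COc1cc(-c2nc3ccccc3s2)ccc1OCC(=O)NNC(=O)CN[C@@H](CCSC)C(=O)O`), which differs from compound 3 as follows: (methylsulfanyl)methyl in place of sulfo on a saturated chain carbon, two bonds along the chain from an amine nitrogen and a carbonyl carbon. This puts (methylsulfanyl)methyl in place of sulfo on a saturated chain carbon, two bonds along the chain from an amine nitrogen and a carbonyl carbon.

Among the measured compounds shown here, the closest guide is the one measured change at this same place, a 1.5-fold higher number from compound 2 to compound 3 (0.18 log units; within the scatter). The larger swaps of the chloro group gave a 1.6-fold higher number from compound 1 to compound 2 (0.20 log units; within the scatter) and a 2.4-fold higher number from compound 1 to compound 3 (0.38 log units; beyond the scatter), so even these steps were small or modest. With only a 1.5-fold higher number from compound 2 to compound 3 (0.18 log units; within the scatter) measured at this place, no step beyond the scatter is expected.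

The expected step is a 1.4-fold lower number from compound 3 to compound 4 (0.16 log units; within the scatter), which is an estimate. For compound 4 the estimated value is 1300 nM, with an expected range from 600 nM to 2600 nM.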

Compound 4, half-maximal inhibitory concentration: 1950 nM
The estimate for compound 4 lay 1.5-fold (0.18 log units) below the measured number, and the stated range covers the measured number.
By their numbers in this assay, from the lowest: compounds 1, 2, 3 and 4 (each within the scatter of the next, the first and the last beyond it).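

In this assay, putting (methylsulfanyl)methyl in place of sulfo gives a 1.0-fold higher number from compound 3 to compound 4 (0.02 log units; within the scatter) and putting it in place of sulfanyl gives a 1.6-fold higher number from compound 2 to compound 4 (0.20 log units; within the scatter) at this saturated chain carbon. Compounds 2, 3 and 4 therefore all lie within the scatter of one another, even though the groups at this place differ widely in their atoms. Replacing chloro with (1-carboxy-3-(methylsulfanyl)propyl)amino gives a 2.5-fold higher number from compound 1 to compound 4 (0.40 log units; beyond the scatter) as a modest step, and no measurement here explains this result or the flat response among compounds 2, 3 and 4.

On these data alone, it remains open whether an amine or a phenyl ring at the end of this side chain would also stay within the scatter. As far as these compounds go, compounds 2, 3 and 4 all carry the carboxylic acid, so the part that acid plays also remains open.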